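Swapping a hydroxy for fluoro on a two-carbon chain

A few compounds are considered here, and "the series" means these few. Any claim that something is new, unique, unknown or untested is made for them only; others in the source may bear on it.

Compound 1 `N#CC1(c2cc(CCO)cc(-c3ccnc4[nH]nc(C(F)(F)F)c34)c2)CC1` carries a 2-hydroxyethyl chain on the shared core. In an ADME assay on S9 fraction from liver (Rattus norvegicus) for metabolic stability, read by LC-MS, using NADPH, with a stated time of 60 min, tested at 10 uM (a lower number here means that less of the compound is left, a higher number that more of the compound is left), compound 1 gives 17%, the second highest of three numbers. Compound 2 `CC(C)C(O)Cc1cc(-c2ccnc3[nH]nc(C(F)(F)F)c23)cc(C2(C#N)CC2)c1` gives 19%, and the step of a number 2 percentage points higher from compound 1 to compound 2 (within the scatter) lies within the scatter. Compound 3 `N#CC1(c2cc(CC(O)C3CC3)cc(-c3ccnc4[nH]nc(C(F)(F)F)c34)c2)CC1` gives 0%, and the step of a number 17 percentage points lower from compound 1 to compound 3 (beyond the scatter) is modest but real; the step of a number 19 percentage points lower from compound 2 to compound 3 (beyond the scatter) is of similar size.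

Compound 4 `N#CC1(c2cc(CCF)cc(-c3ccnc4[nH]nc(C(F)(F)F)c34)c2)CC1` differs from compound 1 in one place: fluoro in place of hydroxy on a saturated chain carbon, two bonds along the chain from an aromatic carbon. Among the compounds with values here, none of the measured steps touches the hydroxy itself; each of them only adds a group to the saturated chain carbon that bears it, so they bear on the new change only indirectly, showing that this chain is a place where the numbers can move by a modest amount. Within the data shown here, with no direct precedent, the expected step of a number 7 percentage points higher from compound 1 to compound 4 (within the scatter) is small and of uncertain direction. Compound 4 is therefore estimated at 24%, within a range from 8% to 50%.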

Compound 4, percent of the compound remaining: 67%
Estimate against measurement, compound 4: 43 percentage points below, and the stated range ends below it.
By their numbers in this assay, from the lowest: compound 3; then compounds 1 and 2 (each within the scatter of the next); then compound 4.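

In this assay, a number 50 percentage points higher from compound 1 to compound 4 (beyond the scatter) is large, whereas the steps that only added a group to the chain carbon bearing the hydroxy were modest or within the scatter. The a number 48 percentage points higher from compound 2 to compound 4 (beyond the scatter) and a number 67 percentage points higher from compound 3 to compound 4 (beyond the scatter) are also large, so compound 4 stands clear of all three hydroxy-bearing compounds, and exchanging the hydroxy moves this number far more than the additions to the chain did. Nothing measured here accounts for the rise.

The compounds shown leave open whether the rise comes from the fluoro itself or simply from the absence of the hydroxy. A methoxy group or a plain ethyl chain at this place would help to separate those two readings, and a fluoro on the branched chains of compound 2 and compound 3 would test how far the change carries.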